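The source may report more compounds than this note shows. Statements on the series, on what has been measured and on what is new or still open speak of the compounds shown alone.

Going by the values given here, in an ADME assay on microsomes from liver (Mus musculus) for metabolic stability, read by LC-MS, with a stated time of 30 min, tested at 1 uM (a higher number here means that more of the compound is left, a lower number that less of the compound is left), compound 1 (`O=C(NCc1ccc(S(=O)(=O)c2cccc(C(F)(F)F)c2)cc1)c1cc2cnccc2[nH]1`) gives 49%, the lower of the only two numbers available. Compound 2 (`O=C(NCc1ccc(S(=O)(=O)c2cccc(C(F)(F)F)c2)cc1)c1cc2ccncc2o1`) gives 64%. Compound 3 (`O=C(NCc1ccc(S(=O)(=O)c2ccc(F)c(F)c2)cc1)c1cc2cnccc2[nH]1`) has not yet been measured. It keeps the core of compound 1 and changes the group on the sulfonyl sulfur, with 3,4-difluorophenyl in place of 3-(trifluoromethyl)phenyl on a sulfonyl sulfur.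

Among the compounds with values here, only one measured step is available for comparison, a number 15 percentage points higher from compound 1 to compound 2 (beyond the scatter). This modest step lies beyond the scatter, but it concerns the group on the carbonyl carbon and leaves the 3-(trifluoromethyl)phenyl untouched. It therefore shows how far this assay moved for a change at another place, and it gives no direction for the present change. Within the data shown here, no measured pair varies the group on the sulfonyl sulfur, so the expectation stays close to the starting value of compound 1, with wide margins on either side. The expected outcome is a number 3 percentage points higher from compound 1 to compound 3 (within the scatter), which means no clear shift in either direction. For compound 3, the estimated value is 52%, with an expected range from 35% to 70%.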

Compound 3, percent of the compound remaining: 58%
Compound 3: the middle estimate sits 6 percentage points below what was measured, and the stated range covers the measured number.
By their numbers in this assay, from the lowest: compounds 1, 3 and 2 (each within the scatter of the next, the first and the last beyond it).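

Going by these compounds alone, this is the first measured change on the sulfonyl sulfur, and in this assay it gives a number 9 percentage points higher from compound 1 to compound 3 (within the scatter) with the core of compound 1 held constant. So 3,4-difluorophenyl can stand in place of 3-(trifluoromethyl)phenyl at this place without a shift that can be told from the usual scatter, even though a group of 10 heavy atoms gives way to one of 8 and the six-membered aromatic ring of carbon only stays. No measurement is available that would explain this reading or tie it to any feature of either group.

The compounds shown leave open how this assay responds on the sulfonyl sulfur to a group without the aromatic ring or without fluorine, such as a cyclohexyl ring, a plain phenyl or an amine, since both groups seen here are fluorinated phenyl rings. Within the data shown here, they also leave open whether 3,4-difluorophenyl on the sulfonyl sulfur gives a similar reading when the group on the carbonyl carbon is that of compound 2, as no pair tests the two changes together.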